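This account rests on a few compounds, and the source may have more. Where it says the series, first, only, none or still open, it means among the compounds named here.

Working notes on the series.

Compound 1 `CN(C)CCn1cnnc1-c1cc(Oc2ccc(NC(=O)N/N=C/c3c(Cl)cccc3Cl)cc2F)ccn1` and compound 2 `CN(C)CCn1cnnc1-c1cc(Oc2ccc(NC(=O)N/N=C/c3ccccc3)cc2F)ccn1` share the same core and differ only at the carbon with a double bond to nitrogen. In a functional assay on MKN-45 cells (Homo sapiens) for cytotoxicity, read by MTT assay, with a stated time of 72 h (on this read-out higher numbers stand for weaker inhibition and lower numbers for stronger inhibition), compound 1 gives 160 nM, and in this assay compound 2 gives 2730 nM. For the measured compounds named here, on the numbers at hand compound 2 stands highest of the two, the single measured step being a 17-fold higher number from compound 1 to compound 2 (1.23 log units; beyond the scatter).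

Compound 3 `CN(C)CCn1cnnc1-c1cc(Oc2ccc(NC(=O)N/N=C/c3ccc(O)c(F)c3)cc2F)ccn1` is not yet measured. Its change from compound 2 is 3-fluoro-4-hydroxyphenyl in place of phenyl on a carbon with a double bond to nitrogen. Going by the values given here, no measured step covers this exact replacement; the only step that bears on it is the one from compound 1 to compound 2, which shows that a substituted ring on that carbon gave a markedly lower number than a bare phenyl, but with different substituents from those entering here. The expectation is therefore a lower number for compound 3 than for compound 2, though a smaller step than the one recorded, expected as a 2.3-fold lower number from compound 2 to compound 3 (0.36 log units; beyond the scatter). The estimate for compound 3 in this assay is 1200 nM, with a range from 300 nM to 4000 nM.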

Compound 3, half-maximal inhibitory concentration: 1970 nM
Beside the measured number, compound 3's estimate is 1.6-fold (0.22 log units) below it; the range from low to high includes it.
By their numbers in this assay, from the lowest: compound 1; then compounds 3 and 2 (each within the scatter of the next).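

In this assay, the step of a 1.4-fold lower number from compound 2 to compound 3 (0.14 log units; within the scatter) shows that on this carbon with a double bond to nitrogen, 3-fluoro-4-hydroxyphenyl cannot be told apart from bare phenyl, even with the added hydrogen-bond donor and acceptor. The step of a 12-fold higher number from compound 1 to compound 3 (1.09 log units; beyond the scatter) lies beyond the scatter, as does a 17-fold higher number from compound 1 to compound 2 (1.23 log units; beyond the scatter), so 2,6-dichlorophenyl in compound 1 stands apart from both other rings. The earlier reading that a substituted ring at this position gives a lower number than phenyl therefore holds for compound 1 only, and compound 3 goes against it as a general pattern.

No information at hand accounts for the separation of compound 1 from the other two. Going by these compounds, it remains open whether the lower number needs both chlorines of the 2,6-dichlorophenyl group or chlorine at all, which a chlorophenyl or a dimethylphenyl group at this carbon would begin to test.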